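Cytotoxicity of thiourea analogues with a chain methyl

A few compounds are considered here, and "the series" means these few. Any claim that something is new, unique, unknown or untested is made for them only; others in the source may bear on it.

Compound 1, `CCNC(=S)Nc1cccc(OCCCCCc2ccccc2)c1`, gives in an ADME assay on Ava5 cells (Homo sapiens) for cytotoxicity (on this read-out higher numbers stand for lower toxicity in this test and lower numbers for higher toxicity in this test), only a limit of the test, > 50000 nM.
Compound 2, `CCCNC(=S)Nc1cccc(OCCCCCc2ccccc2)c1`, gives in this assay 32000 nM.
Compound 3, `NC(=S)Nc1cccc(OCCCCCOc2ccccc2)c1`, gives in this assay only a limit of the test, > 50000 nM.

From compound 1 to compound 2 the change is methyl in place of hydrogen on a saturated chain carbon, two bonds along the chain from an amide-type nitrogen, and the step it made was an at least 1.5-fold lower number from compound 1 to compound 2 (0.19 log units; that floor lies within the scatter). Compound 4, `CC(CCOc1ccccc1)CCOc1cccc(NC(N)=S)c1`, is not yet measured; it differs from compound 3 by methyl in place of hydrogen on a saturated chain carbon bound to two saturated chain carbons. This is the same kind of change, but its place differs: here the carbon is bound to two saturated chain carbons, whereas before it lay two bonds along the chain from an amide-type nitrogen. The difference between the two cores, that of compound 1 and that of compound 3, is not broken down here. Because (the limit of > 50000 nM in this assay, at which 2 of the 3 values shown sit), compound 4 is expected to remain near that limit, so the expected step in this assay is a step that the limit leaves unreadable from compound 3 to compound 4. Compound 4 is estimated at 60000 nM, between 25000 nM and 150000 nM.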

Compound 4, half-maximal cytotoxic concentration: > 50000 nM
Compound 4 gave a limit, no number; the forecaster's own chance of this, stated with the estimate: 70%; the middle value does not contradict the limit.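

Within the data shown here, compound 3 and compound 4 each give only a limit in this assay, and no step between them can be read. The compounds shown leave open whether this added methyl changes the read-out at all.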